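Amide aryl variation on the shared core

The compounds below may be only part of what the source reports. "The series", "measured", "known", "first", "only" and "open" are said of these compounds alone.

Measured compounds:
compound 1 `Cc1ccccc1C(=O)Nc1cccc(-c2oc3cc(-c4ccc(F)cc4)ccc3c(=O)c2O)c1` gives 11900 nM in a functional assay on HeLa cells (Homo sapiens) for antiproliferative activity, read by CCK-8 assay, with a stated time of 72 h; on this read-out lower numbers stand for stronger inhibition and higher numbers for weaker inhibition
compound 2 `O=C(Nc1cccc(-c2oc3cc(-c4ccc(F)cc4)ccc3c(=O)c2O)c1)c1ccc(C(F)(F)F)cc1` gives 17400 nM in this assay
compound 3 `O=C(Nc1cccc(-c2oc3cc(-c4ccc(F)cc4)ccc3c(=O)c2O)c1)c1ccc(-c2ccccc2)cc1` gives > 100000 nM in this assay, which is a limit of the assay and not a number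

Compound 1 holds the lowest of the two numbers shown; compound 2 is nearest, and the move a 1.5-fold higher number from compound 1 to compound 2 (0.17 log units; within the scatter) stays within the scatter, so no order between the two can be read. Compound 3 sits at the limit of > 100000 nM in this assay, at which 1 of the 3 values shown sits. The move an at least 8.4-fold higher number from compound 1 to compound 3 (0.92 log units; beyond the scatter) is beyond the scatter, as is an at least 5.7-fold higher number from compound 2 to compound 3 (0.75 log units; beyond the scatter).

Compound 4 `CCCc1ccc(C(=O)Nc2cccc(-c3oc4cc(-c5ccc(F)cc5)ccc4c(=O)c3O)c2)cc1` has not yet been measured in this assay. It differs from compound 1 by 4-propylphenyl in place of 2-methylphenyl on a carbonyl carbon. All three measured steps bear on this change, since each alters the aryl group on the same carbonyl carbon. Replacing 2-methylphenyl with a 4-substituted phenyl gave a step within the scatter for 4-(trifluoromethyl)phenyl and a step beyond it for 4-phenylphenyl. A 4-propylphenyl is therefore expected to give a number higher than compound 1, with a real chance of reaching the limit.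

Compound 4 is expected to give 30000 nM, with a range from 12000 nM to 100000 nM. This estimate corresponds to an expected step of a 2.5-fold higher number from compound 1 to compound 4 (0.40 log units; beyond the scatter).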

Compound 4, half-maximal inhibitory concentration: 8790 nM
For compound 4 the middle estimate is 3.4-fold (0.53 log units) above the measured one, and the stated range ends above it.
By their numbers in this assay, from the lowest: compounds 4, 1 and 2 (each within the scatter of the next). At a limit, above all of these: compound 3.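

In this assay, 4-propylphenyl on the carbonyl carbon gives a 1.4-fold lower number from compound 1 to compound 4 (0.13 log units; within the scatter), and the propyl-for-trifluoromethyl change gives a 2.0-fold lower number from compound 2 to compound 4 (0.30 log units; within the scatter), so no order can be read among these three compounds. Propyl in place of phenyl on the aromatic carbon gives an at least 11-fold lower number from compound 3 to compound 4 (1.05 log units; beyond the scatter), so the loss seen with compound 3 does not extend to every group on that aromatic carbon, and compounds 2 and 4 both go against any rule that substitution there abolishes activity in this series. Compound 3 holds a limit of the assay and not a number, so the true size of that step stays unknown: the limit of > 100000 nM in this assay, at which 1 of the 4 values shown sits.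

The compounds shown leave open where the change sets in between propyl and phenyl, and how a butyl or hexyl chain, an amine or a carboxylic acid in place of propyl on that aromatic carbon would fall. Also open, going by these compounds, is whether any aryl group on this carbonyl carbon can move the number beyond the scatter under that of compound 1, which gives 11900 nM.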